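The compounds below may be only part of what the source reports. "The series", "measured", "known", "first", "only" and "open" are said of these compounds alone.

In a functional assay on PANC-1 cells (Homo sapiens) for antiproliferative activity, read by MTT assay, with a stated time of 48 h (a lower number here means a stronger inhibitor, a higher number a weaker inhibitor), compound 1 (`COc1ccc(-c2c(Nc3cccc(C(F)(F)F)c3)c3ccc(OC)cc3oc2=O)cc1`) gives 39500 nM and compound 2 (`COc1ccc(-c2c(Nc3ccc(F)cc3)c3ccc(O)cc3oc2=O)cc1`) gives 75100 nM and these two values lie within the usual scatter of each other. Compound 3 (`COc1ccc(-c2c(Nc3ccc(C)cc3)c3ccc(O)cc3oc2=O)cc1`) cannot be placed beside them, since its entry reads "not determined" (no result reported) with no number behind it. Compound 4 (`COc1ccc(-c2c(Nc3cccc(C(F)(F)F)c3)c3ccc(O)cc3oc2=O)cc1`) puts 3-(trifluoromethyl)phenyl in place of 4-methylphenyl on a nitrogen on an aromatic ring and so carries the group also found in compound 1. With no number at the starting end, the step itself cannot be sized, and no direction can be given. In this assay compound 4 is expected to fall with compound 1 and compound 2, with no gap beyond the scatter. For compound 4 the estimated value is 45000 nM with a likely range of 15000 nM to 100000 nM in this measurement.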

Compound 4, half-maximal inhibitory concentration: 67200 nM
Compound 4: middle estimate off by 1.5-fold (0.17 log units), on the low side; measured number inside the range.
By their numbers in this assay, from the lowest: compounds 1, 4 and 2 (each within the scatter of the next).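

In this assay, exchanging 4-fluorophenyl for 3-(trifluoromethyl)phenyl on the nitrogen gives a 1.1-fold lower number from compound 2 to compound 4 (0.05 log units; within the scatter) and so does not separate these two groups. Hydrogen in place of methyl on an oxygen on an aromatic ring gives a 1.7-fold higher number from compound 1 to compound 4 (0.23 log units; within the scatter) and likewise does not separate the two compounds. The step from compound 3 to compound 4 cannot be read, since compound 3 has no number.

Nothing available explains these results. Going by these compounds, whether an amine or a carboxylic acid on that phenyl ring, or a longer chain on that oxygen, would move the number beyond the scatter remains open.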